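This account rests on a few compounds, and the source may have more. Where it says the series, first, only, none or still open, it means among the compounds named here.

Measured compounds:
compound 1 `Clc1ccc(Cc2nn3cc(-c4ccc(Cl)cc4Cl)nc3s2)cc1` — > 250000 nM in an ADME assay on CCRF-CEM cells (Homo sapiens) for cytotoxicity, with a stated time of 72 h; a higher number here means a weaker inhibitor, a lower number a stronger inhibitor
compound 2 `Clc1ccc(Cc2nn3cc(-c4ccccc4)nc3s2)cc1` — > 250000 nM
compound 3 `O=Cc1c(-c2ccc(Cl)cc2Cl)nc2sc(Cc3ccc(Cl)cc3)nn12` — 79000 nM

The value of compound 1 in this assay is a limit of the assay, not a number. The value of compound 2 is likewise a limit. Compound 3 is the only one of the three that gives a number, and the step of an at least 3.1-fold lower number from compound 1 to compound 3 (0.50 log units; beyond the scatter) is read against that limit; it is made by formyl in place of hydrogen on an aromatic carbon, which is also how the core of compound 3 differs from the core of compound 1. Between compound 1 and compound 2 the change is phenyl in place of 2,4-dichlorophenyl on an aromatic carbon, and the step that the two limits leave unreadable from compound 1 to compound 2 is unreadable because of the limit of > 250000 nM in this assay, at which 2 of the 3 values shown sit.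

Compound 4 `O=Cc1c(-c2ccccc2)nc2sc(Cc3ccc(Cl)cc3)nn12` has not been measured. It differs from compound 3 by phenyl in place of 2,4-dichlorophenyl on an aromatic carbon; this is the same kind of change as that from compound 1 to compound 2, the place differing in that here it is also next to the ring atom that bears a formyl group (2 heavy atoms). Since the earlier step gives no readable size, the expectation for compound 4 rests only on the number of compound 3, 79000 nM, and is estimated as a step of a 1.9-fold higher number from compound 3 to compound 4 (0.28 log units; within the scatter). There is also a real chance that for compound 4 only a limit would be reported. Compound 4 is estimated at 150000 nM, expected between 50000 nM and 300000 nM.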

Compound 4, half-maximal inhibitory concentration: 22000 nM
Estimate against measurement, compound 4: 6.8-fold (0.83 log units) above; measured number outside the range, below it.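

In this assay, formyl in place of hydrogen goes with a lower number on both cores, and on the core bearing phenyl it gives an at least 11-fold lower number from compound 2 to compound 4 (1.05 log units; beyond the scatter). So the direction of the change carries over from one core to the other, but its size on each core stays unsettled: the same change on two cores in this assay, an at least 3.1-fold lower number (0.50 log units; beyond the scatter) from compound 1 to compound 3 and an at least 11-fold lower number (1.05 log units; beyond the scatter) from compound 2 to compound 4; the limit leaves it open whether they differ. Compound 1 and compound 2 both stand at a limit of the assay and not at a number: the limit of > 250000 nM in this assay, at which 2 of the 4 values shown sit. Phenyl in place of 2,4-dichlorophenyl can be sized only on the core bearing the formyl group, where it gives a 3.6-fold lower number from compound 3 to compound 4 (0.56 log units; beyond the scatter); the same change from compound 1 to compound 2 cannot be read.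

The compounds shown leave open whether another group in place of the formyl group, such as a carboxylic acid, a hydroxymethyl group or an amine, would give a similar number. They also leave open which of the two chlorines of 2,4-dichlorophenyl accounts for the step to phenyl.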